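This account rests on a few compounds, and the source may have more. Where it says the series, first, only, none or still open, it means among the compounds named here.

In a functional assay on ileum (Cavia porcellus) for antagonist activity (a lower number here means a stronger inhibitor, a higher number a weaker inhibitor), compound 1 `Cc1ccc(CCCCOc2ccc3c(O)c([N+](=O)[O-])c(=O)oc3c2)cc1` gives 2500 nM. Compound 2 `COc1ccc(OCCCOc2ccc3c(O)c([N+](=O)[O-])c(=O)oc3c2)cc1` is reported only as a limit, > 4000 nM. Compound 3 `CC(=O)c1ccc(OCCCOc2ccc3c(O)c([N+](=O)[O-])c(=O)oc3c2)cc1` gives 6100 nM, the higher of the two exact numbers, and compound 1 stands lower by a margin beyond the scatter. Compound 4 `N#Cc1ccc(OCCCOc2ccc3c(O)c([N+](=O)[O-])c(=O)oc3c2)cc1` carries cyano in place of acetyl on an aromatic carbon, para to a large group (cyano in place of acetyl on an aromatic carbon). The group at this position also changes in a step that the limit leaves unreadable from compound 2 to compound 3. The other measured change gives an at least 1.6-fold higher number from compound 1 to compound 2 (0.20 log units; that floor lies within the scatter). Neither step gives a readable size, so no step beyond the scatter is expected in this assay. The expected step is a 1.2-fold lower number from compound 3 to compound 4 (0.09 log units; within the scatter). Compound 4 is estimated at 5000 nM, with an expected range of 2300 nM to 11000 nM.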

Compound 4, half-maximal inhibitory concentration: > 10000 nM
Compound 4: only a limit was reported; the forecaster's own chance of this, stated with the estimate: 30%; middle value at least 2.0-fold (0.30 log units) from the limit.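

Compound 4 is reported in this assay only as a limit, > 10000 nM. Cyano in place of acetyl on this aromatic carbon gives an at least 1.6-fold higher number from compound 3 to compound 4 (0.21 log units; that floor lies within the scatter), so this change shows no readable move toward a stronger inhibitor, while 4-cyanophenoxy in place of 4-methylbenzyl gives an at least 4.0-fold higher number from compound 1 to compound 4 (0.60 log units; beyond the scatter). The step from compound 2 to compound 4 cannot be read. On these data alone, how far compound 4 lies past its limit stays open, as does whether an amine or a carboxylic acid in place of cyano on this aromatic carbon would bring the number down toward that of compound 1.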